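This account rests on a few compounds, and the source may have more. Where it says the series, first, only, none or still open, it means among the compounds named here.

Measured so far in a functional assay on the whole organism (strain Wistar) for inhibition, with Rattus norvegicus as the target, with stated times of 30 min and 3 h, at a dose of 20 mg/kg by the oral route; a lower number here means less inhibition, a higher number more inhibition at the dose given (going by the name of the read-out):
compound 1 `COc1cc(/C=C2\C=C(c3ccc(Cl)cc3)OC2=O)ccc1OC(C)=O` gives 37%;
compound 2 `O=C1/C(=C/c2ccccc2)C=C(c2ccc(Cl)cc2)N1Cc1ccccc1` gives 37%;
compound 3 `O=C1/C(=C/c2ccc(Cl)cc2)C=C(c2ccc(Cl)cc2)N1Cc1ccccc1` gives 88.9%.

Compound 3 stands highest of the three numbers, beyond the scatter from both compound 1 and compound 2, which sit at the same value. Compound 4 `O=C1/C(=C/c2ccc([N+](=O)[O-])cc2)C=C(c2ccc(Cl)cc2)N1Cc1ccccc1` differs from compound 3 by nitro in place of chloro on an aromatic carbon. For the measured compounds named here, the only measured step that touches this position is a number 51.9 percentage points higher from compound 2 to compound 3 (beyond the scatter), a large rise in this assay; it shows the position matters but no measured pair swaps chloro for nitro, so the direction of the change is open. A step of moderate size downward, a number 23.9 percentage points lower from compound 3 to compound 4 (beyond the scatter), is expected, as a hedge toward the two lower values. For compound 4 the estimate in this assay is 65%, within 35% to 95%.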

Compound 4, a percentage reported as inhibition, in the whole organism at one dose (the size of the read-out at that dose, not a potency): 19.8%
The estimate for compound 4 lay 45.2 percentage points above the measured number; measured number below the stated range.
By their numbers in this assay, from the lowest: compound 4; then compounds 1 and 2 (each within the scatter of the next); then compound 3.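

In this assay, nitro in place of chloro gives a number 69.1 percentage points lower from compound 3 to compound 4 (beyond the scatter), so the rise seen with chloro does not extend to every group added at this site. Nitro in place of hydrogen gives a number 17.2 percentage points lower from compound 2 to compound 4 (beyond the scatter), so hydrogen, chloro and nitro here give three separate levels, with nitro lowest. Nothing available accounts for the gap between chloro and nitro.

Still open, going by these compounds, is how an amine or a carboxylic acid would read at this site, and whether the order of the three groups holds with other changes elsewhere on the shared core.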